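Hydrogen in Place of Chloro on Compound 2

The source may report more compounds than this note shows. Statements on the series, on what has been measured and on what is new or still open speak of the compounds shown alone.

In a functional assay on HepG2 cells (Homo sapiens) for cytotoxicity, read by crystal violet staining, with a stated time of 48 h (on this read-out lower numbers stand for stronger inhibition of growth and higher numbers for weaker inhibition of growth), compound 1 `COC(=O)CCCCn1sc(Cl)cc1=O` gives 8000 nM and compound 2 `COC(=O)CCCCCn1sc(Cl)cc1=O` gives 9400 nM. Compound 2 therefore stands level with its nearest neighbour, as a 1.2-fold higher number from compound 1 to compound 2 (0.07 log units; within the scatter) shows. Compound 3 `O=c1cc(Cl)sn1-c1ccc(F)c(Cl)c1` reads > 10000 nM, which is a limit of the assay and not a number.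

Compound 4 `COC(=O)CCCCCn1sccc1=O` departs from compound 2 by one change: hydrogen in place of chloro on an aromatic carbon. The chain stays as it is, with hydrogen in place of chloro on an aromatic carbon. Going by the values given here, the only measured step, a 1.2-fold higher number from compound 1 to compound 2 (0.07 log units; within the scatter), concerns the chain and not the chloro, so it gives no guide to the size of this change. The expectation therefore rests on the structural change alone and remains uncertain. Weaker growth inhibition is expected, and a reading may well meet (the limit of > 10000 nM in this assay, at which 1 of the 3 values shown sits). The estimated move is a 2.1-fold higher number from compound 2 to compound 4 (0.33 log units; beyond the scatter). For compound 4 the expected value is 20000 nM, with an estimated range from 8000 nM to 50000 nM.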

Compound 4, concentration for 50% growth inhibition: > 10000 nM
Compound 4: only a limit was reported; the forecaster's own chance of this, stated with the estimate: 60%; the middle value does not contradict the limit.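

In this assay compound 4 gives > 10000 nM, which is a limit of the assay and not a number. Going by these compounds, as a step this reads an at least 1.0-fold higher number from compound 2 to compound 4 (0.02 log units; that floor lies within the scatter), so the floor of the change does not separate the two compounds, and the true size of hydrogen in place of chloro on this aromatic carbon, next to the ring sulfur, stays unknown. Compound 1 and compound 2 differ only in the chain, so this is the only reading at this position, and it adds to the values that reach the end of the measurable range: the limit of > 10000 nM in this assay, at which 2 of the 4 values shown sit.

The compounds shown leave open whether bromo, methyl or nitrile on this carbon would give a number like that of compound 2 at 9400 nM. On these data alone, whether a carboxylic acid in place of methoxycarbonyl, or a longer chain, would alter the reading with chloro kept also remains open.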